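Replacing a furan amide by a benzyl urea

A few compounds are considered here, and "the series" means these few. Any claim that something is new, unique, unknown or untested is made for them only; others in the source may bear on it.

Of the compounds shown here, three have been measured in an assay on isolated protein with Bile acid receptor (Homo sapiens) as the target; on this read-out higher numbers stand for an effect only at larger amounts of compound and lower numbers for an effect already at smaller amounts. Compound 1, with structure `COC(=O)/C=C/c1cccc(N(Cc2ccc(-c3cccc(OC)c3)cc2)C(=O)NC(C)C)c1`, gives 1370 nM. Compound 2, with structure `CCOC/C=C/c1cccc(N(Cc2ccc(/C=C/C(=O)OC(C)(C)C)cc2)C(=O)C2CCCCC2)c1`, gives 220 nM. Compound 3, with structure `COC(=O)/C=C/c1cccc(N(Cc2ccc(/C=C/C(=O)OC(C)(C)C)cc2)C(=O)c2ccco2)c1`, gives 205 nM. Compound 3 and compound 2 lie within the usual scatter of each other, so nothing separates them; the number for compound 1 is beyond the scatter and clearly higher than that of compound 3.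

Compound 4, with structure `COC(=O)/C=C/c1cccc(N(Cc2ccc(/C=C/C(=O)OC(C)(C)C)cc2)C(=O)NCc2ccccc2)c1`, is not yet measured. It differs from compound 3 in one place: benzylamino in place of furan-2-yl on a carbonyl carbon. In plain words, benzylamino in place of furan-2-yl on a carbonyl carbon, which turns the amide of compound 3 into a urea.

Going by the values given here, no pair of measured compounds differs by only this change, so no directly comparable step exists. Compound 1 also carries a urea, and its number in this assay is the highest of the three, but compound 1 differs from compound 3 in more than one place, so it gives only a loose hint. A moderate rise is expected, with the step from compound 3 to compound 4 estimated at a 2.2-fold higher number from compound 3 to compound 4 (0.34 log units; beyond the scatter). Compound 4 is estimated at 450 nM, with a range from 150 nM to 1400 nM.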

Compound 4, half-maximal effective concentration: > 1000 nM
Compound 4: no number, only a limit (the forecaster's own chance of this, stated with the estimate: 5%); at least 2.2-fold (0.34 log units) between middle value and limit.
By their numbers in this assay, from the lowest: compounds 3 and 2 (each within the scatter of the next); then compound 1.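

In this assay compound 4 gives > 1000 nM, which is a limit of the assay and not a number. Placing benzylamino in place of furan-2-yl on a carbonyl carbon turns the amide into a urea and gives an at least 4.8-fold higher number from compound 3 to compound 4 (0.68 log units; beyond the scatter), the first direct reading of a single change at this position, and it shows that this position does not tolerate every group equally in this assay. The full size of the step cannot be read, because the value for compound 4 stops at a limit: the limit of > 1000 nM in this assay, at which 1 of the 4 values shown sits.

The compounds shown leave open whether the higher number goes with the urea link itself, with the benzyl ring, or simply with the larger group, since the change brings in all of these at once. A phenylacetyl group on that carbonyl carbon would keep the benzyl ring without the urea nitrogen, while a methylamino group would keep the urea without the ring, and either would help separate these possibilities.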